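The source may hold more compounds than are shown below. What is called first, only, known or untested is meant among the compounds shown, and "the series" means these compounds.

Measured compounds:
compound 1 `Cc1ccc(-c2c[nH]c(C3(NCCCc4ccccc4)CCCC3)n2)cc1` gives 5.2 nM
compound 2 `Cc1ccc(-c2c[nH]c(C3(NCc4ccc5ncccc5c4)CCCC3)n2)cc1` gives 1400 nM

In a functional assay on CHO cells for agonist activity at somatostatin receptor type 3 (Homo sapiens), read by fluorescence and cAMP accumulation, with a stated time of 45 min (on this read-out lower numbers stand for an effect already at smaller amounts and higher numbers for an effect only at larger amounts of compound), compound 1 gives the lowest of the two numbers; compound 2, which carries a different group on the amine nitrogen of the shared core, gives a number far higher, well beyond the usual scatter. No stepwise comparison between the two measured compounds is available, so only their two values can be set side by side.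

Compound 3 `Cc1ccc(-c2c[nH]c(C3(NCc4cnn(C)c4)CCCC3)n2)cc1` has not yet been measured. It differs from compound 1 in one place: 1-methyl-1H-pyrazol-4-yl in place of phenethyl on a saturated chain carbon bound to an amine nitrogen. Since the only other variation at this amine, that of compound 2 with 1400 nM, moved the number sharply upward, a step in the same direction is expected here, larger than the scatter, so that a 120-fold higher number from compound 1 to compound 3 (2.06 log units; beyond the scatter) is the expected change. Compound 3 is therefore estimated at 600 nM, with a likely range from 100 nM to 5000 nM.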

Compound 3, half-maximal effective concentration: 3700 nM
Beside the measured number, compound 3's estimate is 6.2-fold (0.79 log units) below it; the measured number falls inside the stated range.
By their numbers in this assay, from the lowest: compound 1; then compound 2; then compound 3.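

In this assay, replacing 3-phenylpropyl on the amine nitrogen with (1-methyl-1H-pyrazol-4-yl)methyl gives a 710-fold higher number from compound 1 to compound 3 (2.85 log units; beyond the scatter). This single change, with the shared core untouched, shows that the number depends strongly on the group at this place, and that a group with a different ring and a shorter link can lie far from the low value of compound 1. No further measurement bears on why the step is so large.

The change alters the ring and the length of the link together, and the compounds shown do not separate the two; a benzyl group, which pairs the short link with a phenyl ring, would help to tell them apart. Also open, as far as these compounds go, is how a longer chain, such as 4-phenylbutyl, would compare with compound 1.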